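Cyclohexyl in place of fluorophenyl on the amide carbonyl

The source may hold more compounds than are shown below. What is called first, only, known or untested is meant among the compounds shown, and "the series" means these compounds.

Compound 1, `O=C(c1ccc(Cl)cc1)N1CCN(c2nc(=O)c3cc(C(F)(F)F)cc([N+](=O)[O-])c3s2)CC1`: in an ADME assay on Vero cells (Chlorocebus sabaeus) for cytotoxicity, read by MTT assay, with a stated time of 72 h (on this read-out lower numbers stand for higher toxicity in this test and higher numbers for lower toxicity in this test), compound 1 gives > 125000 nM, which is a limit of the assay.
Compound 2, `O=C(c1ccc(F)cc1)N1CCN(c2nc(=O)c3cc(C(F)(F)F)cc([N+](=O)[O-])c3s2)CC1`: in this assay compound 2 gives > 125000 nM, which is also a limit.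

Compound 2 stands at the limit, and the other value shown is a limit as well. For the measured compounds named here, the only measured step, a step that the two limits leave unreadable from compound 1 to compound 2, therefore cannot be read, both ends sitting at the limit of > 125000 nM in this assay, at which 2 of the 2 values shown sit. Compound 3, `CC(C)(C)C1CCC(C(=O)N2CCN(c3nc(=O)c4cc(C(F)(F)F)cc([N+](=O)[O-])c4s3)CC2)CC1`, differs from compound 2 by 4-(tert-butyl)cyclohexyl in place of 4-fluorophenyl on a carbonyl carbon. Going by the values given here, no measured step bears on this change; the two limits show only that neither aromatic amide reached a readable toxicity. Compound 3 is expected to stay near that limit, with a step that the limit leaves unreadable from compound 2 to compound 3 that is not beyond the scatter. The estimate for compound 3 in this assay is 150000 nM, within 40000 nM to 500000 nM.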

Compound 3, half-maximal cytotoxic concentration: > 125000 nM
Compound 3: only a limit was reported (the forecaster's own chance of this, stated with the estimate: 65%); the middle value lies beyond the limit too.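

In this assay compound 3 gives > 125000 nM, which is a limit. No step among compound 1, compound 2 and compound 3 can be read: the limit of > 125000 nM in this assay, at which 3 of the 3 values shown sit.

The compounds shown leave open whether 4-chlorophenyl, 4-fluorophenyl and 4-(tert-butyl)cyclohexyl on the carbonyl carbon differ at all in this assay.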